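Hydroxy for methyl on a slowly cleared compound

The source may report more compounds than this note shows. Statements on the series, on what has been measured and on what is new or still open speak of the compounds shown alone.

Compound 1 `CCn1cc2c(Oc3ccc(S(C)(=O)=O)cc3)cc(C(=O)Nc3cnc(C)cn3)cc2n1` and compound 2 `CCCn1cc2c(Oc3ccc(S(C)(=O)=O)cc3)cc(C(=O)Nc3cnc(C)cn3)cc2n1` share one core and differ only in a chain on an aromatic nitrogen. In an in vitro ADME assay on microsomes from liver (Homo sapiens) for metabolic stability (a higher number here means faster removal of the compound, a lower number slower removal), compound 1 gives < 8 mL/min/kg, which is a limit of the assay. In this assay compound 2 gives < 8 mL/min/kg, which is also a limit. Both compounds therefore stand at the limit of < 8 mL/min/kg in this assay, at which 2 of the 2 values shown sit, and neither has an exact number.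

Compound 3 `Cc1cnc(NC(=O)c2cc(Oc3ccc(S(C)(=O)=O)cc3)c3cn(CCO)nc3c2)cn1` alters compound 2 on that chain: hydroxy in place of methyl on a saturated chain carbon, two bonds along the chain from an aromatic nitrogen. Within the data shown here, the one measured step at this place is a step that the two limits leave unreadable from compound 1 to compound 2, which offers no size to carry over. No step beyond the scatter is therefore expected in this assay. The expected size is a step that the limit leaves unreadable from compound 2 to compound 3. For compound 3 the estimated clearance is 6 mL/min/kg, with an expected range of 3 mL/min/kg to 12 mL/min/kg.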

Compound 3, clearance: < 8.9 mL/min/kg
Compound 3: only a limit was reported; the forecaster's own chance of this, stated with the estimate: 75%; the middle value is on the limit's open side.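

In this assay compound 3 gives < 8.9 mL/min/kg, which is a limit. Among these compounds, compound 1, compound 2 and compound 3 all stand at limits, so no step among them can be read. From the compounds shown here alone, the exact clearance of each compound remains open, as does whether their chains make any difference to it.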